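From 2-Chlorophenyl to 4-Methoxyphenyl on an Amide-Type Nitrogen

A few compounds are considered here, and "the series" means these few. Any claim that something is new, unique, unknown or untested is made for them only; others in the source may bear on it.

In a functional assay on MDA-MB-231 cells (Homo sapiens) for antiproliferative activity, read by MTT assay, with a stated time of 24 h (a higher number here means a weaker inhibitor, a lower number a stronger inhibitor), compound 1 `O=C1CC[C@@H](C(=O)N2CCN(c3nccc(Oc4cc(Cl)cc(Cl)c4)n3)CC2)N1` gives > 50000 nM, which is a limit of the assay and not a number. Compound 2 `Cc1ccc(NC(=O)N2CCN(c3nccc(Oc4cc(Cl)cc(Cl)c4)n3)CC2)cc1` gives 11600 nM, and compound 3 `O=C(Nc1ccccc1Cl)N1CCN(c2nccc(Oc3cc(Cl)cc(Cl)c3)n2)CC1` gives 11000 nM. Compound 3 stands level with compound 2 and clear of the limit, with an at least 4.5-fold lower number from compound 1 to compound 3 (0.65 log units; beyond the scatter) and, similarly, an at least 4.3-fold lower number from compound 1 to compound 2 (0.63 log units; beyond the scatter). Compound 4 `COc1ccc(NC(=O)N2CCN(c3nccc(Oc4cc(Cl)cc(Cl)c4)n3)CC2)cc1` carries 4-methoxyphenyl in place of 2-chlorophenyl on an amide-type nitrogen. Among the compounds with values here, the closest precedent is the exchange at that same nitrogen between compound 2 and compound 3, a 1.1-fold lower number from compound 2 to compound 3 (0.02 log units; within the scatter), so no step beyond the scatter is expected. The expected change is a 1.1-fold higher number from compound 3 to compound 4 (0.04 log units; within the scatter). Compound 4 is estimated at 12000 nM, with an expected range from 6000 nM to 25000 nM.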

Compound 4, half-maximal inhibitory concentration: 16400 nM
Compound 4: the middle estimate sits 1.4-fold (0.14 log units) below what was measured; measured number inside the range.
By their numbers in this assay, from the lowest: compounds 3, 2 and 4 (each within the scatter of the next). At a limit, above all of these: compound 1.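

In this assay, the amide-type nitrogen takes 4-methoxyphenyl much as it took the two earlier aromatic groups, with a 1.5-fold higher number from compound 3 to compound 4 (0.17 log units; within the scatter) and a 1.4-fold higher number from compound 2 to compound 4 (0.15 log units; within the scatter). Swapping a chlorine or methyl for a methoxy group thus leaves the three compounds level, and the separation from the 5-oxopyrrolidin-2-yl compound holds, with an at least 3.0-fold lower number from compound 1 to compound 4 (0.48 log units; beyond the scatter). Compound 1 remains a limit of the assay and not a number: the limit of > 50000 nM in this assay, at which 1 of the 4 values shown sits.

As far as these compounds go, what an amine or a carboxylic acid on that aromatic ring would do remains open, as does whether any group at this nitrogen can move the number beyond the scatter of these three compounds.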